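The source may hold more compounds than are shown below. What is called first, only, known or untested is meant among the compounds shown, and "the series" means these compounds.

Measured in a functional assay on MDA-MB-468 cells (Homo sapiens) for antiproliferative activity, read by MTT assay, with a stated time of 72 h; on this read-out lower numbers stand for stronger inhibition and higher numbers for weaker inhibition:
- compound 1 `CCCCn1ccnc1-c1cc(OC)c(OC)c(OC)c1`: 44100 nM
- compound 2 `COc1ccc(-n2ccnc2-c2cc(OC)c(OC)c(OC)c2)cc1[N+](=O)[O-]`: 100 nM

Going by the values given here, of these two, compound 1 holds the higher number, well beyond the usual scatter of repeated measurements from its only neighbour, compound 2. Compound 3 `COc1cc(-c2nccn2-c2cccc(C)c2)cc(OC)c1OC` has not yet been measured. It has 3-methylphenyl in place of butyl on an aromatic nitrogen. No measured pair differs in one place only, so the size of this change has not been shown directly. Among the compounds with values here, the only guide is compound 2, which also carries a six-membered aromatic ring of carbon only on that nitrogen and gives 100 nM. The other groups on that ring differ from those of compound 3, so a close match is not assumed. A step to a lower number, beyond the scatter, is expected: a 44-fold lower number from compound 1 to compound 3 (1.64 log units; beyond the scatter). The estimated value for compound 3 is 1000 nM, with an expected range of 150 nM to 8000 nM.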

Compound 3, half-maximal inhibitory concentration: 22600 nM
Beside the measured number, compound 3's estimate is 23-fold (1.35 log units) below it; the measured number lies above the stated range.
By their numbers in this assay, from the lowest: compound 2; then compounds 3 and 1 (each within the scatter of the next).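

In this assay, the change on the aromatic nitrogen gives a 2.0-fold lower number from compound 1 to compound 3 (0.29 log units; within the scatter), a step that stays within the scatter. Going by these compounds alone, this is the first direct reading at this position, next to the ring atom that bears a large group, and it shows that 3-methylphenyl in place of butyl does not separate the two compounds in this assay, even though the new group brings a six-membered aromatic ring. Nothing measured on these compounds offers an explanation for this result.

Compound 2 differs from compound 3 in more than one place, so the steps to it cannot be read, and the part played by its nitro and methoxy groups remains unresolved. Also open, from the compounds shown here alone, is what a plain phenyl, or an amine or a fluorine atom in place of the methyl on that ring, would give.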